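Moving One Hydroxyl on a Shared Core

The source may hold more compounds than are shown below. What is called first, only, known or untested is meant among the compounds shown, and "the series" means these compounds.

Measured so far:
- Compound 1, `Oc1ccc(-c2cc(-c3cccc(F)c3)cc(-c3ccccc3O)n2)cc1`: > 50000 nM
- Compound 2, `Oc1cccc(-c2cc(-c3ccccc3F)cc(-c3cccc(O)c3)n2)c1`: 16000 nM
- Compound 3, `Oc1cccc(-c2cc(-c3cccc(F)c3)cc(-c3cccc(O)c3)n2)c1`: 1400 nM

In a functional assay on HeLa cells (Homo sapiens) for inhibition (on this read-out higher numbers stand for weaker inhibition and lower numbers for stronger inhibition), compound 3 gives 1400 nM, the lowest of the two numbers shown. The nearest is compound 2, reached by an 11-fold lower number from compound 2 to compound 3 (1.06 log units; beyond the scatter). Compound 1 gives only a limit, > 50000 nM, so it is not a number (the limit of > 50000 nM in this assay, at which 1 of the 3 values shown sits).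

Compound 4, `Oc1ccc(-c2cc(-c3cccc(F)c3)cc(-c3cccc(O)c3)n2)cc1`, is compound 3 with one change: 4-hydroxyphenyl in place of 3-hydroxyphenyl on an aromatic carbon. Within the data shown here, the only measured step, from compound 2 to compound 3, concerns the fluorophenyl group, not a hydroxyphenyl group, so no measured step bears directly on this change. Compound 1, which carries a 4-hydroxyphenyl together with a 2-hydroxyphenyl, shows only a limit, while compound 3 with two 3-hydroxyphenyl groups gives a number; beyond that the data show nothing about a single hydroxyl shift.

From the compounds shown here alone, because the step from compound 2 to compound 3 was an 11-fold lower number from compound 2 to compound 3 (1.06 log units; beyond the scatter), the core tolerates some change, but the hydroxyl move is untested, so a moderate weakening is expected: a 3.6-fold higher number from compound 3 to compound 4 (0.55 log units; beyond the scatter). Compound 4 is therefore estimated at 5000 nM, between 1400 nM and 30000 nM.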

Compound 4, half-maximal inhibitory concentration: 14200 nM
Compound 4: middle estimate off by 2.8-fold (0.45 log units), on the low side; low and high end bracket the measured number.
By their numbers in this assay, from the lowest: compound 3; then compounds 4 and 2 (each within the scatter of the next). At a limit, above all of these: compound 1.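

Moving a single hydroxyl, with the atoms unchanged, is enough to shift the result in this assay: there is a 10-fold higher number from compound 3 to compound 4 (1.01 log units; beyond the scatter), so at this position next to the ring nitrogen, 3-hydroxyphenyl and 4-hydroxyphenyl are not interchangeable. The other hydroxyphenyl position also responds to hydroxyl placement, with an at least 3.5-fold lower number from compound 1 to compound 4 (0.54 log units; beyond the scatter) when 3-hydroxyphenyl replaces 2-hydroxyphenyl. The value of compound 1 is a limit and not a number: the limit of > 50000 nM in this assay, at which 1 of the 4 values shown sits.

The compounds shown leave open whether a different group at this position, such as an amine or a carboxylic acid, would give a lower or higher number than the hydroxyl. They also leave open whether moving the hydroxyl has a similar effect when the shared core carries 2-fluorophenyl, as in compound 2.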